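The compounds below may be only part of what the source reports. "The series", "measured", "known", "first", "only" and "open" are said of these compounds alone.

Of the compounds shown here, three that share one core have been measured so far: compound 1 `CSc1nncc2c(C)nc(C)n12`, compound 2 `CCCc1ncc2cnnc(SC)n12` and compound 3 `CCCc1nc(C)c2c(C(C)C)nnc(SC)n12`, all in a functional assay for inhibition, with Homo sapiens as the target; a higher number here means a weaker inhibitor, a lower number a stronger inhibitor. In this assay compound 1 reaches only the limit of the measurement, > 48000 nM. Compound 2 likewise gives only a limit, > 48000 nM. Compound 3 also gives only a limit, > 48000 nM. Where compound 3 stands is therefore not a number but an edge of the measurement: the limit of > 48000 nM in this assay, at which 3 of the 3 values shown sit, so no step between measured compounds can be read, and nothing in the data ranks the three against each other.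

Compound 4 `CCCc1nc(C)c2cnnc(SC)n12` has not yet been measured. It differs from compound 3 in one place: hydrogen in place of isopropyl on an aromatic carbon. Because the whole measured set sits at the limit of > 48000 nM in this assay, at which 3 of the 3 values shown sit, the author expects no step beyond the usual scatter in this assay for this change, and no direction can be read from the data. The step is expected to be a step that the limit leaves unreadable from compound 3 to compound 4. Compound 4 is thus estimated at 60000 nM, between 20000 nM and 200000 nM, with a limit again the most likely outcome.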

Compound 4, half-maximal inhibitory concentration: > 48000 nM
Compound 4: a limit, no number (the forecaster's own chance of this, stated with the estimate: 85%); the middle value does not contradict the limit.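

In this assay, going by these compounds alone, compound 4 gives only a limit, > 48000 nM, so no step from compound 1, compound 2 or compound 3 to compound 4 can be read: the limit of > 48000 nM in this assay, at which 4 of the 4 values shown sit. The compounds shown leave open how strongly any of them inhibits, and whether any change on the shared core matters.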